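Thiophen-2-yl for 4-chlorophenyl: notes toward compound 3

A few compounds are considered here, and "the series" means these few. Any claim that something is new, unique, unknown or untested is made for them only; others in the source may bear on it.

Measured so far:
compound 1 `Cc1csc(NC(=O)Cn2cc(-c3ccccc3Cl)nn2)n1` — 1240 nM
compound 2 `Cc1csc(NC(=O)Cn2cc(-c3ccc(Cl)cc3)nn2)n1` — 520 nM

In a functional assay on BMDM cells (Mus musculus, strain C57BL/6) for inhibition, with a stated time of 2 days (a higher number here means a weaker inhibitor, a lower number a stronger inhibitor), compound 1 gives 1240 nM, and compound 2 gives 520 nM. Among the compounds with values here, compound 2 thus holds the lower of the two numbers, and the single step of a 2.4-fold lower number from compound 1 to compound 2 (0.38 log units; beyond the scatter) stands beyond the scatter. Compound 3 `Cc1csc(NC(=O)Cn2cc(-c3cccs3)nn2)n1` differs from compound 2 by thiophen-2-yl in place of 4-chlorophenyl on an aromatic carbon. Within the data shown here, the one measured step concerns only which chlorophenyl group occupies that carbon and says nothing about exchanging the ring itself for a different one, so no measured step bears directly on this change. With no precedent in the pair shown, the expectation is a small rise in the number, a 1.5-fold higher number from compound 2 to compound 3 (0.19 log units; within the scatter), carried by a wide range. Compound 3 is therefore estimated to give 800 nM in this assay, with a range from 300 nM to 2500 nM.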

Compound 3, half-maximal inhibitory concentration: 40 nM
The estimate for compound 3 lay 20-fold (1.30 log units) above the measured number, outside the stated range (below it).
By their numbers in this assay, from the lowest: compound 3; then compound 2; then compound 1.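

In this assay, exchanging the ring itself at this aromatic carbon produces a large step in both comparisons (a 13-fold lower number from compound 2 to compound 3 (1.11 log units; beyond the scatter)) and (a 31-fold lower number from compound 1 to compound 3 (1.49 log units; beyond the scatter)), whereas moving the chlorine between the two chlorophenyl groups gave only a modest one (a 2.4-fold lower number from compound 1 to compound 2 (0.38 log units; beyond the scatter)). The position on the five-membered aromatic ring with 3 nitrogen therefore accepts a five-membered aromatic ring with 1 hetero atom in place of a six-membered aromatic ring of carbon only, and the ring type here matters more than the chlorine placement. Nothing available explains this gain.

The compounds shown leave open whether the gain follows the sulfur or the smaller ring, a question that furan-2-yl, thiophen-3-yl or unsubstituted phenyl at this carbon would address. Also open, on these data alone, is whether a methyl group or a chlorine on the thiophene ring would keep the number of compound 3.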